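A few compounds are considered here, and "the series" means these few. Any claim that something is new, unique, unknown or untested is made for them only; others in the source may bear on it.

Two pairs of compounds carry the same kind of change, but they rest on different cores. Compound 1 `COc1ccc(-c2cc(=O)c3c(OC)cc(OC)cc3n2S(=O)(=O)c2ccc(C)c([N+](=O)[O-])c2)cc1` and compound 2 `COc1ccc(-c2cc(=O)c3c(OC)cc(OC)cc3n2S(=O)(=O)c2ccc(C)cc2)cc1` share one core, while compound 3 `COC(=O)c1cc(=O)c2cc(NC(=O)Nc3ccc(C(F)(F)F)cc3[N+](=O)[O-])ccc2[nH]1` and compound 4 `COC(=O)c1cc(=O)c2cc(NC(=O)Nc3ccc(C(F)(F)F)cc3)ccc2[nH]1` share another, and the difference between the two cores is not broken down here. In a functional assay on HepG2 cells (Homo sapiens) for antiproliferative activity, with a stated time of 72 h (on this read-out lower numbers stand for an effect already at smaller amounts and higher numbers for an effect only at larger amounts of compound), compound 1 gives only a limit, > 51700 nM. In this assay compound 2 likewise gives only a limit, > 44800 nM. The change between them is hydrogen in place of nitro on an aromatic carbon, and the step that the two limits leave unreadable from compound 1 to compound 2. In this assay compound 3 also gives only a limit, > 25900 nM. Compound 4 differs from compound 3 by hydrogen in place of nitro on an aromatic carbon, the same kind of change as that from compound 1 to compound 2, though the surroundings differ: in compound 1 the nitro stands ortho to a methyl group and meta to a large group, in compound 3 ortho to a large group and meta to a trifluoromethyl group. The earlier pair offers no readable size for this change, as both its values sit at limits, the limit of > 51700 nM in this assay, at which 1 of the 3 values shown sits, and (the limit of > 44800 nM in this assay, at which 1 of the 3 values shown sits). Compound 4 is therefore expected to show a step that the limit leaves unreadable from compound 3 to compound 4 in this assay, which rests on compound 3 sitting at the limit (the limit of > 25900 nM in this assay, at which 1 of the 3 values shown sits). For compound 4 in this assay an estimate of 40000 nM is expected, spanning 15000 nM to 120000 nM, most likely reported as another limit.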

Compound 4, half-maximal effective concentration: > 6350 nM
Compound 4 was reported as a limit (the forecaster's own chance of this, stated with the estimate: 85%); the middle value is on the limit's open side.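

In this assay compound 3 and compound 4 both give only limits, so the step between them cannot be read, and the same holds for the step between compound 1 and compound 2. The compounds shown leave open whether hydrogen in place of nitro on an aromatic carbon changes the antiproliferative read-out on either core, and if it does, in which direction and by how much.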